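Trading Nitro for Amino on Compound 3

The source may report more compounds than this note shows. Statements on the series, on what has been measured and on what is new or still open speak of the compounds shown alone.

In a functional assay on MCF7 cells (Homo sapiens) for cytotoxicity, read by MTT assay, with a stated time of 96 h (on this read-out lower numbers stand for stronger inhibition and higher numbers for weaker inhibition), compound 3 (`COc1cc(C(=O)c2cn(-c3ccc(N)cc3)cc2-c2cccc([N+](=O)[O-])c2)cc(OC)c1OC`) gives 260 nM, the highest of three numbers, while compound 1 (`COc1cc(C(=O)c2cn(-c3ccc(F)cc3)cc2-c2cccc(N)c2)cc(OC)c1OC`) gives 53 nM and compound 2 (`COc1cc(C(=O)c2cn(-c3ccc(N)cc3)cc2-c2ccccc2[N+](=O)[O-])cc(OC)c1OC`) gives 53 nM. Compound 4 (`COc1cc(C(=O)c2cn(-c3ccc(N)cc3)cc2-c2cccc(N)c2)cc(OC)c1OC`) carries amino in place of nitro on an aromatic carbon. Within the data shown here, the only measured step involving this group, a 4.9-fold higher number from compound 2 to compound 3 (0.69 log units; beyond the scatter), shows that changes on this ring can register. Compound 1 already bears 3-aminophenyl, though it also differs elsewhere, and it gives 53 nM. A step of similar modest size towards a lower number therefore seems likely in this assay. The expected change is a 3.7-fold lower number from compound 3 to compound 4 (0.57 log units; beyond the scatter). For compound 4 the estimated value is 70 nM, within a range from 20 nM to 220 nM.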

Compound 4, half-maximal inhibitory concentration: 78 nM
For compound 4 the middle estimate is 1.1-fold (0.05 log units) below the measured one; low and high end bracket the measured number.
By their numbers in this assay, from the lowest: compounds 1, 2 and 4 (each within the scatter of the next); then compound 3.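

Replacing 3-nitrophenyl with 3-aminophenyl in this assay gives a 3.3-fold lower number from compound 3 to compound 4 (0.52 log units; beyond the scatter) and so shows that the group at this position matters, not only where the nitro sits. Changing 2-nitrophenyl to 3-aminophenyl gives a 1.5-fold higher number from compound 2 to compound 4 (0.17 log units; within the scatter) and so separates neither group from the other. Amino in place of fluoro on an aromatic carbon gives a 1.5-fold higher number from compound 1 to compound 4 (0.17 log units; within the scatter) and likewise separates neither compound. From the compounds shown here alone, whether a hydroxyl group or a carboxylic acid at this position would match amino remains open. Nothing shown here explains why these numbers differ.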